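The source may report more compounds than this note shows. Statements on the series, on what has been measured and on what is new or still open speak of the compounds shown alone.

Measured in an ADME assay on Vero cells (Chlorocebus sabaeus) for cytotoxicity, read by MTT assay, with a stated time of 72 h; a higher number here means that more compound is tolerated, a lower number that less compound is tolerated:
Compound 1 `C[C@]1(CN2CCc3nc(-c4ccc(C#N)cc4)ccc3C2)Cn2cc([N+](=O)[O-])nc2O1`: "not determined" (no result reported)
Compound 2 `C[C@]1(CN2CCc3nc(-c4ccc(F)c(F)c4)ccc3C2)Cn2cc([N+](=O)[O-])nc2O1`: > 32 ug/mL
Compound 3 `C[C@]1(CN2CCc3nc(-c4cccc(Cl)c4F)ccc3C2)Cn2cc([N+](=O)[O-])nc2O1`: > 32 ug/mL

Compound 3 is known only as a limit of this assay, > 32 ug/mL, and not as a number. The result for compound 2, > 32 ug/mL, is also a limit. Compound 1 has no result to compare: "not determined" (no result reported).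

In compound 4 `C[C@]1(CN2CCc3nc(-c4cc(F)cc(Cl)c4)ccc3C2)Cn2cc([N+](=O)[O-])nc2O1`, 3-chloro-5-fluorophenyl takes the place of 3-chloro-2-fluorophenyl on an aromatic carbon: 3-chloro-5-fluorophenyl in place of 3-chloro-2-fluorophenyl on an aromatic carbon. Within the data shown here, the one measured step that bears on this, a step that the two limits leave unreadable from compound 2 to compound 3, exchanges the substituted phenyl at the same place, and its size cannot be read. All that the numbers show is the limit of > 32 ug/mL in this assay, at which 2 of the 3 values shown sit. No step beyond the scatter is therefore expected in this assay, in either direction, and a further limit is the likely report. The estimated step is a step that the limit leaves unreadable from compound 3 to compound 4. For compound 4 the expected value is 40 ug/mL, with an estimated range of 18 ug/mL to 90 ug/mL.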

Compound 4, half-maximal cytotoxic concentration: > 32 ug/mL
Compound 4: only a limit was reported; the forecaster's own chance of this, stated with the estimate: 85%; the middle value is on the limit's open side.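

In this assay, among these compounds, compound 4 gives > 32 ug/mL, a limit and not a number, so no step linking it to compound 2 or compound 3 can be read. The compounds shown leave open what concentration of any of these three compounds is actually tolerated.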